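The source may report more compounds than this note shows. Statements on the series, on what has been measured and on what is new or still open speak of the compounds shown alone.

For the measured compounds named here, compound 1 `COc1cccc(-n2cc(COc3c(/C=C\C(=O)O)ccc(OC)c3CC=C(C)C)nn2)c1` is the only member of this small set with a number: in a functional assay on T47D cells (Homo sapiens) for cytotoxicity, read by MTT assay, with a stated time of 24 h (a higher number here means a weaker inhibitor, a lower number a stronger inhibitor), compound 1 gives 20400 nM. Compound 2 `COc1ccc(-n2cc(COc3c(/C=C\C(=O)O)ccc(OC)c3CC=C(C)C)nn2)cc1` differs from it only in where the methoxy sits on the outer ring, and in this assay compound 2 is recorded as "not determined" (no result reported), so it stands on no number at all. Compound 3 `COc1ccc(/C=C\C(=O)O)c(OCc2cn(-c3ccc(C#N)cc3)nn2)c1CC=C(C)C` carries the change (cyano in place of methoxy on an aromatic carbon). Going by the values given here, with no measured step to guide the size of this change, no shift beyond the usual scatter is expected, and compound 3 is estimated at 20000 nM, within a range from 7000 nM to 60000 nM.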

Compound 3, half-maximal inhibitory concentration: 10200 nM
Compound 3: middle estimate off by 2.0-fold (0.29 log units), on the high side; measured number inside the range.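

For the compounds shown here, compound 3 gives the first reading of a nitrile on the outer ring: in this assay the record shows a 2.0-fold lower number from compound 1 to compound 3 (0.30 log units; within the scatter) and so does not separate 4-cyanophenyl from 3-methoxyphenyl. That swap alters both the group and its place at once, and compound 2 has no number that would isolate cyano against methoxy at the same place. No measurement shown explains this result. Still open, going by these compounds, is how an amine or a carboxylic acid on the outer ring would read, and whether 3-cyanophenyl would match compound 3.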